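The source may hold more compounds than are shown below. What is called first, only, known or untested is meant among the compounds shown, and "the series" means these compounds.

Measured in an ADME assay on L02 cells (Homo sapiens) for cytotoxicity, read by MTT assay, with a stated time of 48 h; on this read-out lower numbers stand for stronger inhibition and higher numbers for weaker inhibition:
- compound 1 `CCN(CC)CCNC(=O)c1ccc(C(CC)(CC)c2ccc(OCC(O)C(C)(C)C)c(C)c2)n1CC`: 2500 nM
- compound 2 `CCn1c(C(=O)NCC(OC)OC)ccc1C(CC)(CC)c1ccc(OCC(O)C(C)(C)C)c(C)c1`: 22200 nM
- compound 3 `CCn1c(C(=O)N(CCC#N)CCC#N)ccc1C(CC)(CC)c1ccc(OCC(O)C(C)(C)C)c(C)c1`: 1700 nM

Compound 3 sits at the low end of these values, which it shares with compound 1 within the scatter: the step is a 1.5-fold lower number from compound 1 to compound 3 (0.17 log units; within the scatter). Far larger is a 13-fold lower number from compound 2 to compound 3 (1.12 log units; beyond the scatter).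

Compound 4 `CCn1c(C(=O)N(C)CC(=O)O)ccc1C(CC)(CC)c1ccc(OCC(O)C(C)(C)C)c(C)c1` differs by a group of 6 heavy atoms (3 carbon, 1 nitrogen, 2 oxygen; no ring) in place of a group of 9 heavy atoms (6 carbon, 3 nitrogen; no ring), on a carbonyl carbon; the entering group is (carboxymethyl)(methyl)amino.

All three measured steps change the group on this carbonyl carbon. Of the three groups, only compound 2 carries oxygen, and it stands apart, an 8.9-fold higher number from compound 1 to compound 2 (0.95 log units; beyond the scatter). The group in compound 4 also holds oxygen, so a value near compound 2 is expected, though this rests on that single compound. The expected change in this assay is large and towards a higher number, a 12-fold higher number from compound 3 to compound 4 (1.07 log units; beyond the scatter). The estimate for compound 4 is 20000 nM, with an expected range of 6000 nM to 60000 nM.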

Compound 4, half-maximal inhibitory concentration: 32600 nM
Estimate against measurement, compound 4: 1.6-fold (0.21 log units) below, and the stated range covers the measured number.
By their numbers in this assay, from the lowest: compounds 3 and 1 (each within the scatter of the next); then compounds 2 and 4 (each within the scatter of the next).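

In this assay the two oxygen-holding groups on the carbonyl carbon now agree, with a 1.5-fold higher number from compound 2 to compound 4 (0.17 log units; within the scatter) between them. The two groups without oxygen stand apart from (carboxymethyl)(methyl)amino, with a 19-fold higher number from compound 3 to compound 4 (1.28 log units; beyond the scatter) and a 13-fold higher number from compound 1 to compound 4 (1.12 log units; beyond the scatter) on record, so this split in the series no longer rests on compound 2 alone. Nothing measured here accounts for the split.

As far as these compounds go, whether the split follows oxygen at all remains open. A methyl ester in place of the carboxylic acid of compound 4, or a plain butylamino group on the same carbonyl carbon, would test this.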